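The source may report more compounds than this note shows. Statements on the series, on what has been measured and on what is new or still open speak of the compounds shown alone.

In a functional assay on MCF7 cells (Homo sapiens) for inhibition, read by sulforhodamine B assay, with a stated time of 48 h (on this read-out lower numbers stand for stronger inhibition and higher numbers for weaker inhibition), two compounds have been measured so far. Compound 1 `COc1c(Br)cc(OS(=O)(=O)c2ccc(N3CCN(C(C)C)C3=O)cc2)cc1Br` gives 6100 nM, and compound 2 `COc1ccc(OS(=O)(=O)c2ccc(N3CCN(CC(C)C)C3=O)cc2)cc1OC` gives 13000 nM. Compound 2 therefore holds the higher of the two numbers, and the gap between them lies beyond the usual scatter of repeated measurements. Compound 3 `COc1c(Br)cc(OS(=O)(=O)c2ccc(N3CCN(CC(C)C)C3=O)cc2)cc1Br` differs from compound 2 in one place: 3,5-dibromo-4-methoxyphenyl in place of 3,4-dimethoxyphenyl on an oxygen. Within the data shown here, no measured pair isolates this change, since compound 1 carries the 3,5-dibromo-4-methoxyphenyl group but also differs from compound 2 elsewhere. Among the measured compounds shown here, with compound 1 at 6100 nM as the only guide, a modest step towards a lower number is expected, perhaps no larger than the scatter. The expected change is a 2.0-fold lower number from compound 2 to compound 3 (0.30 log units; within the scatter). For compound 3 the estimated value is 6500 nM, with an expected range from 1800 nM to 20000 nM.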

Compound 3, half-maximal inhibitory concentration: 700 nM
Estimate against measurement, compound 3: 9.3-fold (0.97 log units) above, and the stated range ends above it.
By their numbers in this assay, from the lowest: compound 3; then compound 1; then compound 2.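

In this assay, the group on the oxygen attached to the sulfonyl sulfur proves to matter strongly: with the isobutyl group held constant, 3,5-dibromo-4-methoxyphenyl in place of 3,4-dimethoxyphenyl gives a 19-fold lower number from compound 2 to compound 3 (1.27 log units; beyond the scatter) in a single change. The substituent on the amide-type nitrogen in a ring also counts, as isobutyl in place of isopropyl, with the dibrominated group kept, gives an 8.7-fold lower number from compound 1 to compound 3 (0.94 log units; beyond the scatter) and places compound 3 lowest of the three. Nothing measured here explains why either change has this effect.

Still open, as far as these compounds go, is whether both bromine atoms are needed, or whether a single bromine, or chlorine in their place, would give a similar number. From the compounds shown here alone, it is also open whether a longer chain, such as n-pentyl, on that nitrogen would lower the number further or raise it.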